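The source may report more compounds than this note shows. Statements on the series, on what has been measured and on what is new or still open speak of the compounds shown alone.

The measured compounds:

Compound 1, `Nc1sc2c(c1-c1nc3ccccc3s1)CCCC2`: in an ADME assay on HepG2 cells (Homo sapiens) for cytotoxicity, read by MTT assay, with a stated time of 72 h (on this read-out lower numbers stand for higher toxicity in this test and higher numbers for lower toxicity in this test), compound 1 gives 163 ug/mL.
Compound 2, `C(=N/c1sc2c(c1-c1nc3ccccc3s1)CCCC2)\c1ccccc1`: in this assay compound 2 gives 308 ug/mL.

Compound 2 holds the higher of the two numbers, but its nearest neighbour, compound 1, sits within the scatter of it, as the step of a 1.9-fold higher number from compound 1 to compound 2 (0.28 log units; within the scatter) shows. Compound 3 is `O=[N+]([O-])c1ccc(/C=N/c2sc3c(c2-c2nc4ccccc4s2)CCCC3)cc1`. It differs from compound 2 by nitro in place of hydrogen on an aromatic carbon. Among the measured compounds shown here, only one measured step exists, the one from compound 1 to compound 2, which concerns the group on the amino nitrogen and not the phenyl ring itself; it stayed within the scatter (a 1.9-fold higher number from compound 1 to compound 2 (0.28 log units; within the scatter)). For the measured compounds named here, no measured pair shows a nitro group entering, so nothing in the data supports a shift beyond the scatter in this assay. Compound 3 is therefore expected to come out near compound 2, at an estimated 250 ug/mL with a range from 100 ug/mL to 600 ug/mL, which means an expected step of a 1.2-fold lower number from compound 2 to compound 3 (0.09 log units; within the scatter).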

Compound 3, half-maximal cytotoxic concentration: 454 ug/mL
The estimate for compound 3 lay 1.8-fold (0.26 log units) below the measured number; low and high end bracket the measured number.
By their numbers in this assay, from the lowest: compounds 1, 2 and 3 (each within the scatter of the next, the first and the last beyond it).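

Among the compounds shown here, compound 3 gives the first reading of a change on the phenyl ring itself, and nitro placed para to a large group leaves the number within the scatter (a 1.5-fold higher number from compound 2 to compound 3 (0.17 log units; within the scatter)) in this assay. On this read-out, then, the phenyl of compound 2 and the 4-nitrophenyl of compound 3 cannot be told apart, so this position accepts nitro without a step that can be distinguished from repeat variation. Nothing available bears on why the number for compound 3 falls where it does.

As far as these compounds go, whether an amine, a carboxylic acid or a methoxy group at this same place would also stay within the scatter remains open. For the compounds shown here, with only one substituent on this ring in view, no trend with the nature of the group can be drawn.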